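This account rests on a few compounds, and the source may have more. Where it says the series, first, only, none or still open, it means among the compounds named here.

Measured so far in a functional assay on CHO cells for antagonist activity at prostaglandin E2 receptor EP4 subtype (Homo sapiens), read by calcium flux, with a stated time of 15 min; on this read-out higher numbers stand for weaker inhibition and lower numbers for stronger inhibition:
compound 1 `C[C@H](NC(=O)c1nnn(Cc2ccc(C(F)(F)F)cc2)c1-c1ccccc1)c1ccc(C(=O)O)cc1`: > 10000 nM
compound 2 `CCc1nnn(Cc2ccc(C(F)(F)F)cc2)c1C(=O)N[C@@H](C)c1ccc(C(=O)O)cc1`: > 10000 nM
compound 3 `COc1ccc(Cn2nnc(-c3ccccc3)c2C(=O)N[C@@H](C)c2ccc(C(=O)O)cc2)cc1`: 9.3 nM

Compound 1 sits at a limit of this assay, not at a number. Compound 2 likewise sits at a limit. Among the measured compounds shown here, compound 3 therefore stands as the only compound with a measured number in this assay; the limit of > 10000 nM in this assay, at which 2 of the 3 values shown sit, holds the other two.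

Compound 4 `C[C@H](NC(=O)c1c(-c2ccccc2)nnn1CC1CCCCC1)c1ccc(C(=O)O)cc1` has not yet been measured. It differs from compound 3 in one place: cyclohexyl in place of 4-methoxyphenyl on a saturated chain carbon bound to an aromatic nitrogen. For the measured compounds named here, no measured pair shows what such a change does here, so the direction and size of the step are uncertain.

The estimated step from compound 3 to compound 4 is a 4.3-fold higher number from compound 3 to compound 4 (0.63 log units; beyond the scatter). For compound 4 the expected value is 40 nM, within a range from 8 nM to 300 nM.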

Compound 4, half-maximal inhibitory concentration: > 10000 nM
Compound 4 gave a limit, no number (the forecaster's own chance of this, stated with the estimate: 10%); at least 250-fold (2.39 log units) between middle value and limit.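

Among the compounds shown here, the first measured change at this position, cyclohexyl in place of 4-methoxyphenyl on a saturated chain carbon bound to an aromatic nitrogen, is an at least 1000-fold higher number from compound 3 to compound 4 (3.03 log units; beyond the scatter). Going by these compounds, for compound 4, > 10000 nM is a limit of the assay and not a number, so the full size of the step stays unknown. A six-membered ring at this place is therefore not enough in itself: of these two rings, only 4-methoxyphenyl gives a measured number.

The compounds shown leave open whether the methoxy group or the aromatic ring matters more. An unsubstituted phenyl on the same carbon would help separate the two.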